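A Return to an Aryl Group on the Ring Nitrogen

A few compounds are considered here, and "the series" means these few. Any claim that something is new, unique, unknown or untested is made for them only; others in the source may bear on it.

Compound 1 `Nc1scc(CN2CCN(c3ccc(F)cc3Cl)CC2)c1C(=O)c1ccc(Cl)cc1` gives 0% in an assay on CHO cells for displacement of a labelled ligand from adenosine receptor A3 (Homo sapiens), read by scintillation counting, with a stated time of 120 min, tested at 10 uM; on this read-out lower numbers stand for less inhibition and higher numbers for more inhibition at the one concentration tested (going by the name of the read-out). Compound 2 `Nc1scc(CN2CCN(c3ccc(C(F)(F)F)cc3)CC2)c1C(=O)c1cccc(C(F)(F)F)c1` gives 0%. Compound 3 `Nc1scc(CN2CCN(C3CCCC3)CC2)c1C(=O)c1ccc(Cl)cc1` gives 3%.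

Compound 3 holds the highest of the three numbers, yet its gaps to compound 1 and compound 2 both lie within the scatter, so nothing separates the three. Compound 4 `Nc1scc(CN2CCN(c3ccccc3Cl)CC2)c1C(=O)c1ccc(Cl)cc1` differs from compound 3 by 2-chlorophenyl in place of cyclopentyl on an amine nitrogen in a ring. Going by the values given here, the one measured step that bears on this place, a number 3 percentage points higher from compound 1 to compound 3 (within the scatter), swapped an aryl group for cyclopentyl and moved nothing beyond the scatter; compound 4 reverses that direction with a closely related aryl group. No step beyond the scatter is therefore expected for compound 4, a number 2 percentage points lower from compound 3 to compound 4 (within the scatter). Compound 4 is estimated at 1%, with a range from -6% to 8%.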

Compound 4, a percentage reported as inhibition, at one concentration (the size of the read-out at that concentration, not a potency): 0%
Estimate against measurement, compound 4: 1 percentage points above; the measured number falls inside the stated range.
By their numbers in this assay, from the lowest: compounds 1, 2, 4 and 3 (each within the scatter of the next).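

Setting 2-chlorophenyl in place of cyclopentyl on the amine nitrogen in a ring gives a number 3 percentage points lower from compound 3 to compound 4 (within the scatter) in this assay, so this aryl group, like the 2-chloro-4-fluorophenyl of compound 1, is not told apart from cyclopentyl at this position. Hydrogen in place of fluoro on the aromatic carbon gives no change at the digits printed from compound 1 to compound 4 (within the scatter), so this change also shows no effect on the number. Nothing at hand offers a reason for these results. On these data alone, whether an amine or a carboxylic acid on this aryl ring, or a longer chain on the ring nitrogen, would lift the number stays open.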